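The source may hold more compounds than are shown below. What is called first, only, known or untested is meant among the compounds shown, and "the series" means these compounds.

Compound 1, `COc1ccc(Cl)cc1C(=O)Nc1ccc(C2=NN(C)C(c3ccccc3[N+](=O)[O-])C2)cc1`, in a functional assay on the whole organism (strain albino) with Rattus norvegicus as the target, read by paw edema, with stated times of 1 h and 4 h, at a dose of 50 mg/kg by the oral route (a lower number here means a weaker effect, a higher number a stronger effect of the compound at the dose given), gives 99.5%.
Compound 2, `COc1ccc(Cl)cc1C(=O)Nc1ccc(C2=NN(c3ccccc3)C(c3ccccc3[N+](=O)[O-])C2)cc1`, in this assay gives 88.4%.

Compound 2 stands lowest of the two numbers. For the measured compounds named here, the one measured step, a number 11.1 percentage points lower from compound 1 to compound 2 (beyond the scatter), concerns the same ring nitrogen and is the only step that bears on the change at hand. Compound 3, `COc1ccc(Cl)cc1C(=O)Nc1ccc(C2=NN(C(C)=O)C(c3ccccc3[N+](=O)[O-])C2)cc1`, differs from compound 2 in acetyl in place of phenyl on an amine nitrogen in a ring. Going by the values given here, no measured compound carries an acetyl at that position, so the acetyl is untested. The step of a number 1.6 percentage points higher from compound 2 to compound 3 (within the scatter) is therefore expected to stay within the scatter. Compound 3 is estimated to give 90%, in a range from 70% to 100%.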

Compound 3, a percentage reported as activity, at one dose (the size of the read-out at that dose, not a potency): 96.2%
Compound 3: the middle estimate sits 6.2 percentage points below what was measured, and the stated range covers the measured number.
By their numbers in this assay, from the lowest: compounds 2, 3 and 1 (each within the scatter of the next, the first and the last beyond it).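

In this assay the acetyl on the amine nitrogen in the ring gives a number 7.8 percentage points higher from compound 2 to compound 3 (within the scatter), and against the methyl it gives a number 3.3 percentage points lower from compound 1 to compound 3 (within the scatter). Compound 3 therefore cannot be told apart from either neighbour, although compound 1 and compound 2 are separated beyond the scatter, so the acetyl, with no ring and one hydrogen-bond acceptor, sits within reach of both. Nothing available explains the readings at this nitrogen. Going by these compounds, whether a longer acyl chain such as butanoyl, a benzoyl group or a plain hydrogen on this nitrogen would read the same remains open.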